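Chloro on the benzoyl ring of compound 2

The compounds below may be only part of what the source reports. "The series", "measured", "known", "first", "only" and "open" are said of these compounds alone.

Three members of this series have numbers in a functional assay on A549 cells (Homo sapiens) for antiproliferative activity, read by MTT assay, with a stated time of 24 h; on this read-out higher numbers stand for weaker inhibition and lower numbers for stronger inhibition. Compound 1 `COc1cc(-c2cc(C(=O)/C=C/c3ccc(Cl)cc3)nc3cc(-c4ccccc4)nn23)cc(OC)c1OC` gives 23800 nM. Compound 2 `COc1cc(-c2cc(/C=C/C(=O)c3ccccc3)nc3cc(-c4ccccc4)nn23)cc(OC)c1OC` gives 18200 nM, the second highest of the three; its nearest neighbour is compound 1, and a 1.3-fold lower number from compound 1 to compound 2 (0.12 log units; within the scatter). Compound 3 `COc1ccc(-c2cc(/C=C/C(=O)c3ccccc3)nc3cc(-c4ccccc4)nn23)cc1` gives 8600 nM, and a 2.1-fold lower number from compound 2 to compound 3 (0.33 log units; beyond the scatter). Compound 4 `COc1cc(-c2cc(/C=C/C(=O)c3ccc(Cl)cc3)nc3cc(-c4ccccc4)nn23)cc(OC)c1OC` is not yet measured. It differs from compound 2 by chloro in place of hydrogen on an aromatic carbon, placed on an aromatic carbon of a six-membered aromatic ring of carbon only, para to a large group; read one bond further out, benzoyl becomes (4-chlorophenyl)carbonyl. Going by the values given here, the only measured step that touches a chloro on a phenyl at this end of the molecule is the one from compound 1 to compound 2, and it stays within the scatter. No step beyond the scatter is therefore expected for the step from compound 2 to compound 4, so a 1.1-fold higher number from compound 2 to compound 4 (0.04 log units; within the scatter) is the estimate. Compound 4 is expected to give 20000 nM in this assay, with a range from 8000 nM to 50000 nM.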

Compound 4, half-maximal inhibitory concentration: 15500 nM
Compound 4: the middle estimate sits 1.3-fold (0.11 log units) above what was measured; the range from low to high includes it.
By their numbers in this assay, from the lowest: compounds 3, 4, 2 and 1 (each within the scatter of the next, the first and the last beyond it).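

In this assay the chloro can now be read alone: 4-chlorophenyl in place of phenyl gives a 1.2-fold lower number from compound 2 to compound 4 (0.07 log units; within the scatter) and so makes no change beyond the scatter at this position. The earlier step between compound 1 and compound 2 carried two differences at once, whereas with the chloro kept on both sides, 2-((4-chlorophenyl)carbonyl)ethenyl in place of (2-(4-chlorophenyl)ethenyl)carbonyl gives a 1.5-fold lower number from compound 1 to compound 4 (0.19 log units; within the scatter) and also stays within the scatter. No supporting data bear on these small steps.

Still open, going by these compounds, is whether an amine or a carboxylic acid in place of the chloro at this position would give a step beyond the scatter. Also open, on these data alone, is whether chloro in place of hydrogen gives a similar step with the 4-methoxyphenyl group of compound 3.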